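This account rests on a few compounds, and the source may have more. Where it says the series, first, only, none or still open, it means among the compounds named here.

Measured so far in a functional assay on MKN-45 cells (Homo sapiens) for cytotoxicity, read by MTT assay, with a stated time of 72 h; a higher number here means a weaker inhibitor, a lower number a stronger inhibitor:
compound 1 `CN(C)CCn1cnnc1-c1cc(Oc2ccc(NC(=O)N/N=C/c3cccc(Br)c3)cc2F)ccn1` gives 450 nM
compound 2 `CN(C)CCn1cnnc1-c1cc(Oc2ccc(NC(=O)N/N=C/c3ccc(O)cc3)cc2F)ccn1` gives 820 nM
compound 3 `CN(C)CCn1cnnc1-c1cc(Oc2ccc(NC(=O)N/N=C/c3ccc(O)c(Br)c3)cc2F)ccn1` gives 1860 nM

Compound 3 stands highest of the three numbers in this assay; the nearest of the others is separated from it by a 2.3-fold higher number from compound 2 to compound 3 (0.36 log units; beyond the scatter) and the furthest by a 4.1-fold higher number from compound 1 to compound 3 (0.62 log units; beyond the scatter). Compound 4 `CN(C)CCn1cnnc1-c1cc(Oc2ccc(NC(=O)N/N=C/c3ccc(O)cc3O)cc2F)ccn1` differs from compound 3 in one place: 2,4-dihydroxyphenyl in place of 3-bromo-4-hydroxyphenyl on a carbon with a double bond to nitrogen. Going by the values given here, two measured steps bear on this change. Removing bromo reverses a 2.3-fold higher number from compound 2 to compound 3 (0.36 log units; beyond the scatter), which points toward a lower number. Adding a hydroxy resembles a 4.1-fold higher number from compound 1 to compound 3 (0.62 log units; beyond the scatter), which raised the number. Taken together, a modest fall is expected, a 1.9-fold lower number from compound 3 to compound 4 (0.27 log units; within the scatter), landing near compound 2. Compound 4 is therefore estimated to give about 1000 nM, within a range from 400 nM to 2500 nM.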

Compound 4, half-maximal inhibitory concentration: 2860 nM
Beside the measured number, compound 4's estimate is 2.9-fold (0.46 log units) below it, and the stated range ends below it.
By their numbers in this assay, from the lowest: compounds 1 and 2 (each within the scatter of the next); then compounds 3 and 4 (each within the scatter of the next).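

In this assay, 2,4-dihydroxyphenyl in place of 3-bromo-4-hydroxyphenyl gives a 1.5-fold higher number from compound 3 to compound 4 (0.19 log units; within the scatter), so at this position the two groups are not separated, while the same 2,4-dihydroxyphenyl stands clearly apart from 4-hydroxyphenyl, with a 3.5-fold higher number from compound 2 to compound 4 (0.54 log units; beyond the scatter), and from 3-bromophenyl, with a 6.4-fold higher number from compound 1 to compound 4 (0.80 log units; beyond the scatter). Adding a hydroxy to the aromatic ring has now raised the number twice, by similar amounts: the same change on two cores in this assay, a 4.1-fold higher number (0.62 log units; beyond the scatter) from compound 1 to compound 3 and a 3.5-fold higher number (0.54 log units; beyond the scatter) from compound 2 to compound 4, 1.2-fold (0.07 log units) apart, within the scatter of two such steps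

The compounds shown leave open whether a methoxy or an amine on the same ring would raise the number as a hydroxy does. They also leave open how a carboxylic acid would fare there.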